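The source may hold more compounds than are shown below. What is called first, only, known or untested is meant among the compounds shown, and "the series" means these compounds.

Of the compounds shown here, three built on one shared core have been tested in a functional assay on SAOS-2 cells (Homo sapiens) for antiproliferative activity, read by MTT assay, with a stated time of 72 h; on this read-out higher numbers stand for weaker inhibition and lower numbers for stronger inhibition. Compound 1 `CC(C)OC1=C(C(=O)c2ccccc2)C(c2ccc(Br)cc2)N(CCCn2ccnc2)C1=O` gives 23000 nM, compound 2 `CCCCCOC1=C(C(=O)c2ccccc2)C(c2ccc(Br)cc2)N(CCCn2ccnc2)C1=O` gives 9990 nM, and compound 3 `NC1=C(C(=O)c2ccccc2)C(c2ccc(Br)cc2)N(CCCn2ccnc2)C1=O` gives 107000 nM, the highest number of the three. The steps of a 4.7-fold higher number from compound 1 to compound 3 (0.67 log units; beyond the scatter) and an 11-fold higher number from compound 2 to compound 3 (1.03 log units; beyond the scatter) show that exchanging an alkoxy group for amino raised the number, pentyloxy more than isopropoxy, in line with a 2.3-fold lower number from compound 1 to compound 2 (0.36 log units; beyond the scatter). Compound 4 `CCOc1ccc(NC2=C(C(=O)c3ccccc3)C(c3ccc(Br)cc3)N(CCCn3ccnc3)C2=O)cc1` carries 4-ethoxyphenyl in place of hydrogen on an amine nitrogen. Going by the values given here, no measured step adds anything to this nitrogen, so the comparison is indirect, yet a modest fall in this assay is expected for compound 4, estimated at 20000 nM within a range of 5000 nM to 70000 nM. The implied step a 5.4-fold lower number from compound 3 to compound 4 (0.73 log units; beyond the scatter) is an expectation only.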

Compound 4, half-maximal inhibitory concentration: 30900 nM
Compound 4: middle estimate off by 1.5-fold (0.19 log units), on the low side, within the range that was stated.
By their numbers in this assay, from the lowest: compound 2; then compounds 1 and 4 (each within the scatter of the next); then compound 3.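

Putting 4-ethoxyphenyl on the amine nitrogen gives a 3.5-fold lower number from compound 3 to compound 4 (0.54 log units; beyond the scatter) in this assay, so this nitrogen can carry an aromatic ring while the number falls. With (4-ethoxyphenyl)amino in place of isopropoxy the result is a 1.3-fold higher number from compound 1 to compound 4 (0.13 log units; within the scatter), but in place of pentyloxy it is a 3.1-fold higher number from compound 2 to compound 4 (0.49 log units; beyond the scatter), so the substituted amine matches the isopropoxy group but not the pentyloxy group. Nothing measured here gives a reason for these shifts.

From the compounds shown here alone, whether the ethoxy group contributes, or an unsubstituted phenyl ring would serve equally, remains open. So does the outcome with a simple alkyl chain, such as pentyl, on this nitrogen.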